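A few compounds are considered here, and "the series" means these few. Any claim that something is new, unique, unknown or untested is made for them only; others in the source may bear on it.

In a physicochemical assay for solubility, read by chemiluminescence, measured as kinetic solubility (a higher number here means a more soluble compound, a lower number a less soluble compound), compound 1 `CC(=O)NCc1cccc(Cn2nc(NS(=O)(=O)c3ccc(Cl)s3)c3c(F)cccc32)c1` reads >= 139 ug/mL, which is a limit of the assay and not a number. For the measured compounds named here, compound 2 `COc1cccc2c1c(NS(=O)(=O)c1ccc(Cl)c(Cl)c1)nn2Cc1cccc(CNC(=O)C(C)(C)O)c1` gives 76 ug/mL, the only actual number available so far. The next compound, compound 3 `COc1cccc2c1c(NS(=O)(=O)c1cccc(Cl)c1Cl)nn2Cc1cccc(CNC(=O)C(C)(C)O)c1`, differs from compound 2 in one place: 2,3-dichlorophenyl in place of 3,4-dichlorophenyl on a sulfonyl sulfur. It carries 2,3-dichlorophenyl in place of 3,4-dichlorophenyl on a sulfonyl sulfur, with the same atoms joined differently. Going by the values given here, no measured pair shows this kind of change, and the two groups match in everything counted for them. Starting from compound 2 at 76 ug/mL, no shift beyond the scatter is expected in this assay, and no direction can be favoured. The expected step of a 1.1-fold higher number from compound 2 to compound 3 (0.02 log units; within the scatter) is therefore small. Compound 3 is estimated at 80 ug/mL, with an expected range of 40 ug/mL to 140 ug/mL.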

Compound 3, solubility: 157 ug/mL
Compound 3: middle estimate off by 2.0-fold (0.29 log units), on the low side; measured number outside the range, above it.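

In this assay, 2,3-dichlorophenyl in place of 3,4-dichlorophenyl on a sulfonyl sulfur gives a 2.1-fold higher number from compound 2 to compound 3 (0.32 log units; beyond the scatter). For the compounds shown here, this is the first readable step, and it shows that the read-out at this position is not indifferent to how the same atoms are joined, even though the two groups match in everything counted for them. Compound 1 offers no comparison here, and its reading is a limit of the assay: the limit of >= 139 ug/mL in this assay, at which 1 of the 3 values shown sits.

Going by these compounds alone, the single pair gives the size of this one change and no cause for it, so it remains open whether a monochlorophenyl group, a pyridyl ring or a nitrile in place of a chlorine would move the number in the same direction. On these data alone, whether the step carries over to the core of compound 1 also remains open.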